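This account rests on a few compounds, and the source may have more. Where it says the series, first, only, none or still open, it means among the compounds named here.

In an ADME assay on HepG2 cells (Homo sapiens) for cytotoxicity, in the presence of a further agent that is not named here (on this read-out lower numbers stand for stronger inhibition and higher numbers for weaker inhibition), three compounds of a shared core have so far been measured, and none of them has returned a number. Compound 1, with the structure `Cc1nc(C(=O)NCc2ccccc2)c(O)c(=O)n1C`, sits at the limit of the assay, its reading being given only as > 100000 nM. Compound 2, with the structure `Cn1c(Cc2ccccc2C(F)(F)F)nc(C(=O)Nc2ccccc2)c(O)c1=O`, likewise stops at the limit and shows > 100000 nM. Compound 3, with the structure `COc1nc(C(C)c2ccccc2C(F)(F)F)nc(C(=O)NCc2ccccc2)c1O`, is again a limit and gives > 100000 nM. Within the data shown here, compound 2 therefore stands nowhere apart from the other two; the only evidence in this set is the limit of > 100000 nM in this assay, at which 3 of the 3 values shown sit, and no step between two real numbers can be drawn from it.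

Compound 4, with the structure `Cn1c(Cc2ccccc2C(F)(F)F)nc(C(=O)NCc2ccccn2)c(O)c1=O`, has not yet been measured in this assay. It differs from compound 2 in one place: (pyridin-2-yl)methyl in place of phenyl on an amide-type nitrogen. Among the measured compounds shown here, with every value so far a limit, the step of a number no higher from compound 2 to compound 4 (the limit leaves the size open) is expected to amount to nothing beyond the usual scatter in this assay. For compound 4 the expected reading in this assay is 100000 nM, within a range from 50000 nM to 200000 nM, most likely once more a limit.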

Compound 4, half-maximal inhibitory concentration: > 100000 nM
Compound 4 ended at the assay's limit; the forecaster's own chance of this, stated with the estimate: 85%; the middle value lies on the limit itself.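

In this assay, among these compounds, compound 2 and compound 4 both stand at a limit rather than at a number, so no step between them can be read. The compounds shown leave open at what concentration, if any, any of these four compounds would give a readable value.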